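Compound 2 to compound 3 at the assay limit

The compounds below may be only part of what the source reports. "The series", "measured", "known", "first", "only" and "open" are said of these compounds alone.

In a functional assay on B16-F10 cells (Mus musculus) for antiproliferative activity, read by CCK-8 assay, with a stated time of 48 h (on this read-out higher numbers stand for weaker inhibition and lower numbers for stronger inhibition), compound 1 (`COc1ccc(/C=C\c2cc(OC)c(OC)c(OC)c2)cc1OCc1ccc(CN2C[C@H](O)C[C@@H]2C(=O)O)cc1`) gives > 10000 nM as a limit of the assay, not a number. Compound 2 (`COc1ccc(/C=C\c2cc(OC)c(OC)c(OC)c2)cc1OCc1ccc(CN[C@H](C(=O)O)[C@H](C)O)cc1`) gives > 10000 nM which is likewise only a limit. Compound 2 therefore stands at the limit of > 10000 nM in this assay, at which 2 of the 2 values shown sit, and no number fixes its place.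

Compound 3 (`COc1ccc(/C=C\c2cc(OC)c(OC)c(OC)c2)cc1OCc1ccc(CN2CC[C@H](C(=O)O)C2)cc1`) keeps the shared core and changes one group (3-carboxypyrrolidin-1-yl in place of (1-carboxy-2-hydroxypropyl)amino on a saturated chain carbon bound to an aromatic carbon), with 3-carboxypyrrolidin-1-yl in place of (1-carboxy-2-hydroxypropyl)amino on a saturated chain carbon bound to an aromatic carbon. Going by the values given here, the one measured step that bears on this is a step that the two limits leave unreadable from compound 1 to compound 2 and it offers no size to carry over, though it changed the group at the same place.

Since compound 2 shows > 10000 nM as a limit, no step beyond the scatter is expected in this assay and no direction can be named. The estimated step is a step that the limit leaves unreadable from compound 2 to compound 3 and the reading is expected to be a limit again. Compound 3 is estimated at 15000 nM with an expected range of 6000 nM to 40000 nM in that read-out.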

Compound 3, half-maximal inhibitory concentration: 7000 nM
Beside the measured number, compound 3's estimate is 2.1-fold (0.33 log units) above it; measured number inside the range.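

In this assay, compound 3 gives 7000 nM, the only number among the three compounds shown. A change on this saturated chain carbon bound to an aromatic carbon can therefore bring the reading off the limit. Putting 3-carboxypyrrolidin-1-yl in place of (1-carboxy-2-hydroxypropyl)amino gives an at least 1.4-fold lower number from compound 2 to compound 3 (0.15 log units; that floor lies within the scatter), and putting it in place of 2-carboxy-4-hydroxypyrrolidin-1-yl gives an at least 1.4-fold lower number from compound 1 to compound 3 (0.15 log units; that floor lies within the scatter). Both steps are only floors, so they establish a readable value for compound 3 but no gain beyond the scatter, and the step between the two limit compounds, compound 1 and compound 2, cannot be read.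

How far compound 1 and compound 2 actually lie from compound 3 remains unknown, as neither has a number: the limit of > 10000 nM in this assay, at which 2 of the 3 values shown sit.

Also open, going by these compounds, is whether the carboxylic acid on the pyrrolidine ring is needed at all, which a methyl ester or a primary amide at this place would address, and whether a six-membered piperidine ring carrying the same carboxylic acid would read any differently.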